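This account rests on a few compounds, and the source may have more. Where it says the series, first, only, none or still open, it means among the compounds named here.

Measured so far:
compound 1, `CCCCCCCCCO[C@@H]1[C@@H](N)[C@@H](OCC(O)CNCCO)O[C@H](CN)[C@H]1OCCCCCCCCC`, 10.1%
compound 2, `NC[C@H]1O[C@H](O[C@H]2[C@H](OCCCc3ccc4ccccc4c3)[C@@H](O)[C@H](N)C[C@@H]2N)[C@H](N)[C@@H](OCCCc2ccc3ccccc3c2)[C@@H]1O`, 89.5%
compound 3, `C=CCO[C@H]1O[C@H](CN)[C@@H](OCCCc2ccc3ccccc3c2)[C@H](OCCCc2ccc3ccccc3c2)[C@H]1N`, 7%

In a toxicity assay on the whole organism (J774 cells) for cytotoxicity, with Mus musculus as the target, read by MTT assay, with a stated time of 24 h, tested at 30 uM (on this read-out higher numbers stand for a weaker effect at the one concentration tested and lower numbers for a stronger effect), compound 1 gives the second highest of the three numbers. Compound 3 lies nearest, within the scatter of it, so no order between the two can be read; compound 2 lies far higher, beyond the scatter. Compound 4, `CCCCCCCCCO[C@@H]1[C@@H](N)[C@@H](OC[C@H](O)CN)O[C@H](CN)[C@H]1OCCCCCCCCC`, differs from compound 1 in one place: 2-amino-1-hydroxyethyl in place of 1-hydroxy-2-((2-hydroxyethyl)amino)ethyl on a saturated chain carbon bound to an oxygen on a saturated carbon. Going by the values given here, no step between two measured compounds matches this change, so there is nothing to set its size from; a step of no more than the scatter in this assay is expected, in either direction. Compound 4 is therefore expected to give about 12%, with a range from 3% to 30%, meaning an expected step of a number 1.9 percentage points higher from compound 1 to compound 4 (within the scatter).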

Compound 4, a percentage reported as activity, at one concentration (the size of the read-out at that concentration, not a potency): 14.4%
Estimate against measurement, compound 4: 2.4 percentage points below; the measured number falls inside the stated range.
By their numbers in this assay, from the lowest: compounds 3, 1 and 4 (each within the scatter of the next); then compound 2.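

In this assay, putting 2-amino-1-hydroxyethyl in place of 1-hydroxy-2-((2-hydroxyethyl)amino)ethyl gives a number 4.3 percentage points higher from compound 1 to compound 4 (within the scatter). Going by these compounds alone, this is the first single-place comparison, and it shows that this group, on a saturated chain carbon bound to an oxygen on a saturated carbon, can lose heavy atoms without a readable change in the number. No measurement at hand speaks to the cause. From the compounds shown here alone, whether a carboxylic acid or a longer chain at this place would also stay within the scatter of compound 1 remains open. So does whether the same change would behave alike on another core.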